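From pyrrolidin-1-yl to a silicon-bearing group

This account rests on a few compounds, and the source may have more. Where it says the series, first, only, none or still open, it means among the compounds named here.

Measured in a functional assay on SMMC-7721 cells (Homo sapiens) for antiproliferative activity, read by MTT assay, with a stated time of 48 h; a lower number here means a stronger inhibitor, a higher number a weaker inhibitor:
Compound 1 `CC(C)=CCC[C@]1(C)/C=C/[C@@H](OC(=O)C=C(C)C)[C@](C)(O)/C=C/C(=O)/C(C(=O)O)=C\C1`: > 10000 nM (a limit)
Compound 2 `CC(C)=CCC[C@]1(C)/C=C/[C@@H](OC(=O)C=C(C)C)[C@](C)(O)/C=C/C(=O)/C(CN2CCCC2)=C\C1`: 140 nM

Among the compounds with values here, compound 2 holds the only true number in this assay, at 140 nM. Compound 1 is known only by a limit. Within the data shown here, the one measured step, an at least 71-fold lower number from compound 1 to compound 2 (1.85 log units; beyond the scatter), is large and put (pyrrolidin-1-yl)methyl in place of carboxy on a double-bonded ring carbon.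

Compound 3 `CC(C)=CCC[C@]1(C)/C=C/[C@@H](OC(=O)C=C(C)C)[C@](C)(O)/C=C/C(=O)/C(C[Si](C)(C)C(C)(C)C)=C\C1` keeps the shared core and differs from compound 2 in one place: a group of 7 heavy atoms (6 carbon, 1 silicon; no ring) in place of a group of 5 heavy atoms (4 carbon, 1 nitrogen; one five-membered non-aromatic ring with 1 hetero atom), on a saturated chain carbon bound to a double-bonded ring carbon. The measured step bears on this change only in part. Among the measured compounds shown here, it shows that the group carried on that ring carbon can shift the result strongly, yet no measured compound carries anything like the new group. For the measured compounds named here, with the step from compound 1 as the sole guide, an at least 71-fold lower number from compound 1 to compound 2 (1.85 log units; beyond the scatter), a moderate move towards a higher number is expected in this assay, well short of that step's full size, and the uncertainty is wide. The estimated change is a 6.4-fold higher number from compound 2 to compound 3 (0.81 log units; beyond the scatter). Compound 3 is expected at 900 nM, with an estimated range of 180 nM to 6000 nM.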

Compound 3, half-maximal inhibitory concentration: 4000 nM
The estimate for compound 3 lay 4.4-fold (0.65 log units) below the measured number, and the stated range covers the measured number.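

In this assay, the group carried on the saturated chain carbon bound to the double-bonded ring carbon matters in its own right: with the rest of the molecule unchanged, putting the silicon-bearing group in place of pyrrolidin-1-yl gives a 29-fold higher number from compound 2 to compound 3 (1.46 log units; beyond the scatter). The large gain seen earlier therefore does not come with just any group replacing carboxy on the double-bonded ring carbon, although the silicon-bearing compound still reads better than the acid, with an at least 2.5-fold lower number from compound 1 to compound 3 (0.39 log units; beyond the scatter). Compound 1 is known only by a limit, so this last step is a bound and not a full size: the limit of > 10000 nM in this assay, at which 1 of the 3 values shown sits.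

The swap changes several things at once, silicon for nitrogen, no ring for a five-membered ring, and no hydrogen-bond acceptor for one, and the compounds shown cannot separate these. They leave open what an open-chain amine such as diethylamino, a six-membered ring amine such as piperidine or morpholine, or an all-carbon group such as neopentyl would give at this place.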